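A few compounds are considered here, and "the series" means these few. Any claim that something is new, unique, unknown or untested is made for them only; others in the source may bear on it.

In a functional assay on cells (Cancer cell lines, Homo sapiens) for inhibition (on this read-out higher numbers stand for weaker inhibition of growth and lower numbers for stronger inhibition of growth), compound 3 `Cc1cc(-c2nc3n(c2/C=N/NC(=N)N)CCS3)c(C)s1` gives 29500 nM, within the scatter of compound 1 `N=C(N)N/N=C/c1c(-c2cc(Cl)sc2Cl)nc2n1CCS2` at 16200 nM. Compound 2 `Cc1cn2c(/C=N/NC(=N)N)c(-c3cccs3)nc2s1`, which has a different core and carries a thiophen-2-yl, gives 8130 nM, a lower number than compound 3 by more than the scatter.

Compound 4 `N=C(N)N/N=C/c1c(-c2cccs2)nc2n1CCS2` keeps the core of compound 3 and has not yet been measured. The change is thiophen-2-yl in place of 2,5-dimethylthiophen-3-yl on an aromatic carbon.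

Among the compounds with values here, only one measured step bears directly on this place: a 1.8-fold higher number from compound 1 to compound 3 (0.26 log units; within the scatter). It exchanges one substituted thiophen-3-yl for another, so it stays within the scatter but does not test a thiophen-2-yl on this core. Within the data shown here, the only other guide is compound 2 at 8130 nM, whose core differs. A small step towards a lower number is therefore expected, with no large shift.

The estimated step is a 2.0-fold lower number from compound 3 to compound 4 (0.29 log units; within the scatter). Compound 4 is expected at about 15000 nM, with an estimated range from 6500 nM to 33000 nM.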

Compound 4, concentration for total growth inhibition: 38900 nM
Beside the measured number, compound 4's estimate is 2.6-fold (0.41 log units) below it; measured number outside the range, above it.
By their numbers in this assay, from the lowest: compounds 2, 1, 3 and 4 (each within the scatter of the next, the first and the last beyond it).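

In this assay, within the data shown here, placing thiophen-2-yl on this aromatic carbon of the shared core gives a 1.3-fold higher number from compound 3 to compound 4 (0.12 log units; within the scatter) and so tests, as the earlier compounds did not, a thiophene joined through its 2-position in this place. Set against the chlorinated group, the same thiophen-2-yl gives a 2.4-fold higher number from compound 1 to compound 4 (0.38 log units; beyond the scatter) and this is the first step at this position to pass the scatter, though it remains modest and the 2,5-dichlorothiophen-3-yl of compound 1 is the only group here separated from thiophen-2-yl in this way. No measurement shown explains either step.

The compounds shown carry only thiophene rings at this position, so they leave open how a phenyl ring, or a thiophene bearing an amine or a carboxylic acid, would behave there. They also leave open whether the 2,5-dichlorothiophen-3-yl keeps its edge over thiophen-2-yl on the core of compound 2.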